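The source may report more compounds than this note shows. Statements on the series, on what has been measured and on what is new or still open speak of the compounds shown alone.

Working notes on the series. Among the measured compounds shown here, compound 1 `Cc1nc(-c2ccccc2NCC2=NCCN2)cs1` stands highest of the two numbers measured so far: in a functional assay for activation of Alpha-1B adrenergic receptor (Homo sapiens), read by calcium flux (on this read-out higher numbers stand for an effect only at larger amounts of compound and lower numbers for an effect already at smaller amounts), compound 1 gives 69.2 nM. For the measured compounds named here, compound 2 `c1csc(-c2ccccc2NCC2=NCCN2)c1` gives 5.75 nM in this assay, so the single measured step, a 12-fold lower number from compound 1 to compound 2 (1.08 log units; beyond the scatter), is large and runs toward stronger activation. Next in line is compound 3 `c1ccc(-c2ccccc2NCC2=NCCN2)nc1`, which differs from compound 1 as follows: pyridin-2-yl in place of 2-methyl-1,3-thiazol-4-yl on an aromatic carbon. Going by the values given here, the exchange sits at the same place, on an aromatic carbon ortho to a group of 7 heavy atoms, so the step from compound 1 to compound 2 is the only measured step that bears on it. Pyridin-2-yl, however, is a six-membered aromatic ring with 1 hetero atom, where the group that leaves is five-membered with 2, so how much of the gain carries over is open. A gain is expected, a 3.5-fold lower number from compound 1 to compound 3 (0.54 log units; beyond the scatter), smaller than the measured one. Compound 3 is estimated at 20 nM, with a range from 4 nM to 100 nM in this assay.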

Compound 3, half-maximal effective concentration: 30.2 nM
The estimate for compound 3 lay 1.5-fold (0.18 log units) below the measured number, and the stated range covers the measured number.
By their numbers in this assay, from the lowest: compound 2; then compound 3; then compound 1.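

At this position, on an aromatic carbon ortho to a group of 7 heavy atoms, a six-membered aromatic ring can also lower the number: in this assay pyridin-2-yl gives a 2.3-fold lower number from compound 1 to compound 3 (0.36 log units; beyond the scatter) and remains a modest step. Against thiophen-2-yl the same ring gives a 5.3-fold higher number from compound 2 to compound 3 (0.72 log units; beyond the scatter) as a further modest step. Ring size alone therefore does not set the order among these three, since the six-membered pyridin-2-yl falls between the five-membered thiophen-2-yl and 2-methyl-1,3-thiazol-4-yl, and no measurement on hand accounts for this order.

The compounds shown do not separate the effect of the methyl group from that of the thiazole ring, so 1,3-thiazol-4-yl without the methyl remains an open comparison. They also leave open how a plain phenyl ring, with no hetero atom, would stand against these three groups.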